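Swapping the aromatic ring on the amide for a hydroxy group

A few compounds are considered here, and "the series" means these few. Any claim that something is new, unique, unknown or untested is made for them only; others in the source may bear on it.

Compound 3 `CC1(C)Cc2c(sc(NC(=O)c3ccn[nH]3)c2C(N)=O)C(C)(C)O1` gives the lowest number of the three compounds measured in an assay on cells for positive allosteric modulation of Cystic fibrosis transmembrane conductance regulator variant F508del (Homo sapiens), with stated times of 10 min and 7 s, in the presence of a further agent that is not named here (a higher number here means that more compound is needed for the effect, a lower number that less compound is needed), at 3 nM. Its nearest neighbour, compound 2 `CC1(C)Cc2c(sc(NC(=O)c3nnc[nH]3)c2C(N)=O)C(C)(C)O1`, gives 467 nM, and compound 1 `Cc1ccc(C(=O)Nc2sc3c(c2C(N)=O)CCOC3)s1`, which has a different core and a methylthiophene group on the carbonyl carbon, gives 778 nM. For the measured compounds named here, the only measured step in this assay that changes the group on the carbonyl carbon is a 160-fold lower number from compound 2 to compound 3 (2.19 log units; beyond the scatter), which shows that this position is sensitive to even a small change between two five-membered aromatic rings.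

Compound 4 `CC1(C)Cc2c(sc(NC(=O)C(C)(C)O)c2C(N)=O)C(C)(C)O1` has not been measured; it differs from compound 3 in one place: 1-hydroxy-1-methylethyl in place of 1H-pyrazol-5-yl on a carbonyl carbon. Here a ring with a nitrogen-bound hydrogen is replaced by a small chain with a hydroxyl. Because a 160-fold lower number from compound 2 to compound 3 (2.19 log units; beyond the scatter) was large for a subtle ring swap, removing the ring altogether is expected to move the number well beyond the scatter in the upward direction, and the step of a 200-fold higher number from compound 3 to compound 4 (2.30 log units; beyond the scatter) is the expected outcome. Compound 4 is therefore estimated at 600 nM, within a range of 100 nM to 5000 nM.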

Compound 4, half-maximal effective concentration: 16 nM
Estimate against measurement, compound 4: 38-fold (1.57 log units) above; the measured number lies below the stated range.
By their numbers in this assay, from the lowest: compound 3; then compound 4; then compounds 2 and 1 (each within the scatter of the next).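

The aromatic ring is not needed on this carbonyl carbon for a low number: replacing 1H-pyrazol-5-yl with the ringless 1-hydroxy-1-methylethyl gives only a 5.3-fold higher number from compound 3 to compound 4 (0.73 log units; beyond the scatter) in this assay and leaves compound 4 well placed among the compounds shown. The open chain also compares favourably with the other ring, giving a 29-fold lower number from compound 2 to compound 4 (1.47 log units; beyond the scatter) and showing that the choice of group here matters more than whether a ring is present. No measurement shown accounts for either step.

As far as these compounds go, what the hydroxyl itself contributes stays open, and replacing it with an amine or a plain methyl group on the same chain would test this. It is also unclear how a longer chain carrying a hydroxyl would behave at this position.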